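The source may report more compounds than this note shows. Statements on the series, on what has been measured and on what is new or still open speak of the compounds shown alone.

Measured so far:
compound 1, `N=C(N)NCCCNC(=O)C1CCC(=O)N2CC(CCC(=O)O)C2C1`: 1300000 nM
compound 2, `N=C(N)NCCCNC(=O)[C@@H]1CCC(=O)N2C[C@H](CCC(=O)O)[C@H]2C1`: 3100000 nM

Both values come from an assay on a protein complex for binding affinity to integrin alpha-5/beta-1 (Homo sapiens); a lower number here means a stronger inhibitor, a higher number a weaker inhibitor. Compound 2 has the highest number of the two; its nearest neighbour is compound 1, and the step from one to the other was a 2.4-fold higher number from compound 1 to compound 2 (0.38 log units; beyond the scatter), which rests on (the fact that one of compounds 1 and 2 is drawn with a defined configuration and the other without, at the place where they differ).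

Compound 3, `N=C(N)NCCCNC(=O)[C@H]1CCC(=O)N2C[C@H](CCC(=O)O)[C@H]2C1`, keeps every atom and bond of compound 2 and differs only in the two compounds have the same atoms and bonds; at least one stereo element is drawn with a configuration in one of them and without one in the other: 1 of 4 stereo elements differ; a stereocentre at a saturated ring carbon is drawn R in compound 2 and S in compound 3. Within the data shown here, the one measured step, a 2.4-fold higher number from compound 1 to compound 2 (0.38 log units; beyond the scatter), shows that drawing out the configuration moved the number modestly, so a modest step in this assay is expected in either direction. Compound 3 is estimated at 900000 nM, between 250000 nM and 3500000 nM, meaning a 3.4-fold lower number from compound 2 to compound 3 (0.54 log units; beyond the scatter).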

Compound 3, half-maximal inhibitory concentration: 65000 nM
For compound 3 the middle estimate is 14-fold (1.14 log units) above the measured one; measured number outside the range, below it.
By their numbers in this assay, from the lowest: compound 3; then compound 1; then compound 2.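

Configuration at this one saturated ring carbon matters far more than the earlier pair suggested: going from R to S, with no atom or bond changed, gives a 48-fold lower number from compound 2 to compound 3 (1.68 log units; beyond the scatter) in this assay. The other step, a 20-fold lower number from compound 1 to compound 3 (1.30 log units; beyond the scatter), spans three stereo elements, so it cannot be pinned on any one of them. The large single step rests on this: the fact that one of compounds 2 and 3 is drawn with a defined configuration and the other without, at the place where they differ

Still open, from the compounds shown here alone, is what each of the other stereocentres contributes on its own. Also open, going by these compounds, is whether compound 3 would keep its number with an amine in place of the guanidine, or with a longer chain carrying the carboxylic acid.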